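Second acetyl on the amide nitrogen of compound 2

The compounds below may be only part of what the source reports. "The series", "measured", "known", "first", "only" and "open" are said of these compounds alone.

- compound 1 `COc1ccc(-c2c(-c3cc(OC)c(OC)c(OC)c3)noc2N)cc1`: 12000 nM
- compound 2 `COc1ccc(-c2c(-c3cc(OC)c(OC)c(OC)c3)noc2NC(C)=O)cc1`: > 50000 nM (a limit)
- compound 3 `COc1ccc(-c2c(-c3cc(OC)c(OC)c(OC)c3)noc2NC(C)=O)cc1OC`: 46300 nM

In a functional assay on SMMC-7721 cells (Homo sapiens) for cytotoxicity, read by MTT assay, with a stated time of 48 h (a higher number here means a weaker inhibitor, a lower number a stronger inhibitor), compound 2 gives only a limit, > 50000 nM, and no number.

Compound 4 `COc1ccc(-c2c(-c3cc(OC)c(OC)c(OC)c3)noc2N(C(C)=O)C(C)=O)cc1` differs from it as follows: acetyl in place of hydrogen on an amide-type nitrogen. Acetamido thus becomes diacetylamino.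

The closest measured precedent is an at least 4.1-fold higher number from compound 1 to compound 2 (0.61 log units; beyond the scatter), also acetyl in place of hydrogen on a nitrogen, and that step went beyond the scatter towards weaker inhibition. The other step, an at least 1.0-fold lower number from compound 2 to compound 3 (0.03 log units; that floor lies within the scatter), is methoxy in place of hydrogen on an aromatic carbon, and its floor lies within the scatter. In this assay compound 3 gives 46300 nM, so a measured number exists for an acetamido compound.

A second acetyl is expected to leave the read-out at the weak end of the series, possibly again as a limit. The estimated step is a number no higher from compound 2 to compound 4 (the limit leaves the size open), with none expected beyond the scatter. For compound 4 the expected value is 50000 nM, with an estimated range of 25000 nM to 100000 nM.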

Compound 4, half-maximal inhibitory concentration: 1360 nM
Beside the measured number, compound 4's estimate is 37-fold (1.57 log units) above it; measured number below the stated range.
By their numbers in this assay, from the lowest: compound 4; then compound 1; then compound 3. At a limit, above all of these: compound 2.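

In this assay, the second acetyl on the amide-type nitrogen gives an at least 36-fold lower number from compound 2 to compound 4 (1.56 log units; beyond the scatter), against an at least 4.1-fold higher number from compound 1 to compound 2 (0.61 log units; beyond the scatter) for the first acetyl, so acylation at this nitrogen does not act in one direction across the series. The diacetylamino group also improves on the free amino group, with an 8.8-fold lower number from compound 1 to compound 4 (0.95 log units; beyond the scatter), so compound 4 is the only compound shown that improves on compound 1. The size of the step from compound 2 remains a floor, as compound 2 gives only a limit: the limit of > 50000 nM in this assay, at which 1 of the 4 values shown sits.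

Open, going by these compounds, is whether propionyl or benzoyl groups on this nitrogen would match the diacetylamino result, and whether a nitrogen carrying one acetyl and one methyl would do the same. Also open, on these data alone, is how diacetylamino behaves alongside the added methoxy of compound 3.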